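The source may hold more compounds than are shown below. What is called first, only, known or untested is meant among the compounds shown, and "the series" means these compounds.

Compound 3 `CCO/N=C(\CCN1CCN(c2ccc(OC)cc2)CC1)c1ccccc1` gives 5% in a functional assay on HEK293 cells with D(4) dopamine receptor (Homo sapiens) as the target, read by FLIPR (a lower number here means a smaller maximal response, a higher number a larger maximal response), the lowest of the three values in hand; compound 1 `C=CCO/N=C(\CCN1CCN(c2ccccn2)CC1)c1ccccc1` gives 69% and compound 2 `CCO/N=C(\CCN1CCN(c2ccccc2)CC1)c1ccccc1` gives 80%, both beyond the scatter from compound 3. Going by the values given here, the one measured step that changes a single place is a number 75 percentage points lower from compound 2 to compound 3 (beyond the scatter). Compound 4 `CCO/N=C(\CCN1CCN(c2ncccc2C)CC1)c1ccccc1` differs from compound 3 by 3-methylpyridin-2-yl in place of 4-methoxyphenyl on an amine nitrogen in a ring. This removes the methoxy-bearing ring whose arrival went with the large drop from compound 2 to compound 3 and brings in a pyridin-2-yl ring of the sort carried by compound 1; a large rise in this assay is therefore expected, a number 55 percentage points higher from compound 3 to compound 4 (beyond the scatter). For compound 4 the estimated value is 60%, with a range of 25% to 90%.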

Compound 4, largest response reached (reported as efficacy), in percent of the reference or control that the assay uses: 49%
Beside the measured number, compound 4's estimate is 11 percentage points above it, within the range that was stated.
By their numbers in this assay, from the lowest: compound 3; then compound 4; then compound 1; then compound 2.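

On the amine nitrogen in a ring, the aromatic group sets the response in this assay in both directions: a number 44 percentage points higher from compound 3 to compound 4 (beyond the scatter) but a number 31 percentage points lower from compound 2 to compound 4 (beyond the scatter). 3-methylpyridin-2-yl thus recovers much of the response seen with phenyl, though not all of it, and this place accepts a ring with a hetero atom. Nothing available explains either step.

The compounds shown do not separate the contribution of the ring nitrogen from that of the methyl in 3-methylpyridin-2-yl. On these data alone, how a chloro or ethoxy group on the phenyl ring would behave at this place remains open.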